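Solubility notes on a pyrimidine series: step to compound 4

The source may hold more compounds than are shown below. What is called first, only, known or untested is meant among the compounds shown, and "the series" means these compounds.

Measured compounds:
- compound 1 `CS(=O)(=O)Cc1cc([C@]23CCOC[C@H]2C3)nc(-c2cccc(O)c2)n1`: 75 ug/mL
- compound 2 `CCNC(=O)Nc1ccc(-c2nccc(C3=CCOCC3)n2)cc1`: 24 ug/mL
- compound 3 `CC(C)(c1cc([C@@]23CCOC[C@@H]2C3)nc(-c2ccc(NC(=S)NCCO)cc2)n1)S(C)(=O)=O`: 145 ug/mL

In a physicochemical assay for solubility, in phosphate buffer, measured as kinetic solubility, with a stated time of 1 h, at pH 7.4 (on this read-out higher numbers stand for higher solubility and lower numbers for lower solubility), compound 2 stands lowest of the three numbers. Compound 1 sits above it by a margin beyond the scatter, and compound 3 lies furthest above, also beyond the scatter. Within the data shown here, compounds 1 and 3 both carry the bicyclic group that compound 2 lacks, but they differ from compound 2 in several other places as well, so no single step between measured compounds is available.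

Compound 4 `CCNC(=O)Nc1ccc(-c2nccc([C@@]34CCOC[C@@H]3C4)n2)cc1` has not yet been measured in this assay. It differs from compound 2 in one place: a group of 7 heavy atoms (6 carbon, 1 oxygen; one three-membered non-aromatic ring of carbon only, one six-membered non-aromatic ring with 1 hetero atom) in place of a group of 6 heavy atoms (5 carbon, 1 oxygen; one six-membered non-aromatic ring with 1 hetero atom), on an aromatic carbon The one-carbon-larger saturated bicycle replaces a ring that holds one double bond outside aromatic rings; donor and acceptor counts stay the same.

With no directly comparable step on record, the expectation rests on the direction shown by compounds 1 and 3 against compound 2, and the expected step from compound 2 to compound 4 is a 1.5-fold higher number from compound 2 to compound 4 (0.16 log units; within the scatter), a modest rise that may not exceed the scatter. Compound 4 is estimated at 35 ug/mL, within 12 ug/mL to 100 ug/mL.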

Compound 4, solubility: 127 ug/mL
For compound 4 the middle estimate is 3.6-fold (0.56 log units) below the measured one; the measured number lies above the stated range.
By their numbers in this assay, from the lowest: compound 2; then compounds 1, 4 and 3 (each within the scatter of the next).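

In this assay, the bicycle with a three-membered carbon ring and a six-membered ring with 1 hetero atom, in place of the six-membered ring with 1 double bond outside aromatic rings, gives a 5.3-fold higher number from compound 2 to compound 4 (0.72 log units; beyond the scatter). Among these compounds, this is the first single-place step, and it shows that the number responds to a change at this aromatic carbon, next to the ring nitrogen, with the ethyl urea end held constant. Nothing shown accounts for the size of this step.

The change removes the double bond and brings in the three-membered ring at once, and a saturated tetrahydropyranyl group at this place would be needed to tell the two apart. On these data alone, whether the step holds with an amine or a carboxylic acid elsewhere on the compound stays open.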